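Trifluoromethyl for Methyl on the Pendant Phenyl Ring

The source may report more compounds than this note shows. Statements on the series, on what has been measured and on what is new or still open speak of the compounds shown alone.

Compound 1, `Cc1cccc(-c2cc(C)c(Nc3ccnc(Nc4ccc(C#N)cc4)n3)c(C)c2)c1`: 3670 nM
Compound 2, `Cc1cc(-c2ccc(Cl)cc2)cc(C)c1Nc1ccnc(Nc2ccc(C#N)cc2)n1`: 4190 nM

In an ADME assay on MT4 cells (Homo sapiens) for cytotoxicity, read by MTT assay, with a stated time of 4 days (a higher number here means that more compound is tolerated, a lower number that less compound is tolerated), compound 1 gives 3670 nM and compound 2 gives 4190 nM; the step of a 1.1-fold higher number from compound 1 to compound 2 (0.06 log units; within the scatter) lies within the scatter, so neither stands apart from the other on the numbers shown. Compound 3, `Cc1cc(-c2cccc(C(F)(F)F)c2)cc(C)c1Nc1ccnc(Nc2ccc(C#N)cc2)n1`, differs from compound 1 by trifluoromethyl in place of methyl on an aromatic carbon. Among the measured compounds shown here, the only measured step that bears on this change is the one from compound 1 to compound 2, which exchanged the whole pendant ring and hardly moved the number. Because a 1.1-fold higher number from compound 1 to compound 2 (0.06 log units; within the scatter) stayed within the scatter, the step of a 1.0-fold higher number from compound 1 to compound 3 (0.00 log units; within the scatter) is expected to stay within the scatter as well. Compound 3 is therefore estimated at 3700 nM, ranging from 2000 nM to 7000 nM.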

Compound 3, half-maximal cytotoxic concentration: 4030 nM
Beside the measured number, compound 3's estimate is 1.1-fold (0.04 log units) below it, within the range that was stated.
By their numbers in this assay, from the lowest: compounds 1, 3 and 2 (each within the scatter of the next).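

Set against the whole-ring exchange, this step isolates one group in this assay and still finds no separation, with a 1.1-fold higher number from compound 1 to compound 3 (0.04 log units; within the scatter) for trifluoromethyl in place of methyl on the ring. With a 1.0-fold lower number from compound 2 to compound 3 (0.02 log units; within the scatter) as well, the three pendant rings shown cannot be told apart in this read-out, so this position has so far tolerated each of these changes without a shift beyond the scatter. Nothing shown accounts for this. On these data alone, whether an amine or a carboxylic acid in this place would move the number beyond the scatter stays open, as does the outcome for a longer chain there.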